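Compound 4: a Chain Amide Replaces the Aryl Amides

A few compounds are considered here, and "the series" means these few. Any claim that something is new, unique, unknown or untested is made for them only; others in the source may bear on it.

Measured in a functional assay on A549 cells (Homo sapiens) for inhibition, read by MTT assay, with a stated time of 72 h; a higher number here means a weaker inhibitor, a lower number a stronger inhibitor:
compound 1 `COc1ccccc1NC(=O)CCC(=O)OCCCCCCSc1ccc([N+](=O)[O-])c2nonc12` gives 1870 nM
compound 2 `O=C(CCC(=O)OCCCCCCSc1ccc([N+](=O)[O-])c2nonc12)Nc1ccc(Br)cc1` gives 3340 nM
compound 3 `COc1ccc(NC(=O)CCC(=O)OCCCCCCSc2ccc([N+](=O)[O-])c3nonc23)cc1OC` gives 3890 nM

Compound 1 has the lowest number of the three. Its nearest neighbour is compound 2, with a 1.8-fold higher number from compound 1 to compound 2 (0.25 log units; within the scatter); the furthest is compound 3, with a 2.1-fold higher number from compound 1 to compound 3 (0.32 log units; beyond the scatter), a modest step. Between compounds 2 and 3 lies a 1.2-fold higher number from compound 2 to compound 3 (0.07 log units; within the scatter).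

Compound 4 `CCN(CC)CCCNC(=O)CCC(=O)OCCCCCCSc1ccc([N+](=O)[O-])c2nonc12` differs from compound 1 in one place: 3-(diethylamino)propyl in place of 2-methoxyphenyl on an amide-type nitrogen. Every measured step exchanges one aromatic group for another on the same amide-type nitrogen, and all of them were small. None removes the ring altogether, so they speak only loosely to this change. Among the compounds with values here, with no closer precedent, compound 4 is expected to land near compound 1, with a 1.5-fold higher number from compound 1 to compound 4 (0.18 log units; within the scatter) as the estimated step and a wide range. The estimated value for compound 4 in this assay is 2800 nM, from 900 nM to 9000 nM.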

Compound 4, half-maximal inhibitory concentration: 2570 nM
Compound 4: the middle estimate sits 1.1-fold (0.04 log units) above what was measured; measured number inside the range.
By their numbers in this assay, from the lowest: compounds 1, 4, 2 and 3 (each within the scatter of the next, the first and the last beyond it).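

At this amide-type nitrogen, an open 3-(diethylamino)propyl chain can stand in place of the aromatic ring with no step beyond the scatter in this assay (a 1.4-fold higher number from compound 1 to compound 4 (0.14 log units; within the scatter); a 1.3-fold lower number from compound 2 to compound 4 (0.11 log units; within the scatter); a 1.5-fold lower number from compound 3 to compound 4 (0.18 log units; within the scatter)). Among these four compounds, then, a ring on this nitrogen is not needed for a number in this range. Nothing available explains this result.

On these data alone, it remains open whether a plain hexyl chain without the amine would do the same. A carboxylic acid at the chain end is also untested here.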